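Benzazole anilides: cytotoxicity limits and a fluoro analogue

The source may report more compounds than this note shows. Statements on the series, on what has been measured and on what is new or still open speak of the compounds shown alone.

Compound 1 `Cc1ccc(-c2nc3ccccc3s2)cc1NC(=O)c1cc([N+](=O)[O-])ccc1Cl` gives > 14000 nM in an ADME assay on HEK293 cells (Homo sapiens) for cytotoxicity, with a stated time of 72 h (on this read-out lower numbers stand for an effect already at smaller amounts and higher numbers for an effect only at larger amounts of compound), a value that is a limit of the assay and not a number.
Compound 2 `O=C(Nc1cc(-c2nc3ccccc3s2)ccc1F)c1cc([N+](=O)[O-])ccc1Cl` gives > 25000 nM in this assay, which is again a limit of the assay.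
Compound 3 `Cc1ccc(-c2nc3ccccc3o2)cc1NC(=O)c1cc([N+](=O)[O-])ccc1Cl` gives > 14000 nM in this assay, also a limit of the assay.

All three measured compounds share the same amide core and differ in one place each. From compound 1 to compound 2 the change is fluoro in place of methyl on an aromatic carbon, and the step is a step that the two limits leave unreadable from compound 1 to compound 2. From compound 1 to compound 3 the change is 1,3-benzoxazol-2-yl in place of 1,3-benzothiazol-2-yl on an aromatic carbon, with the step that the two limits leave unreadable from compound 1 to compound 3. Because both values sit at limits, namely the limit of > 14000 nM in this assay, at which 2 of the 3 values shown sit, and (the limit of > 25000 nM in this assay, at which 1 of the 3 values shown sits), neither step can be given a size.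

Compound 4 `O=C(Nc1cc(-c2nc3ccccc3o2)ccc1F)c1cc([N+](=O)[O-])ccc1Cl` is not yet measured. It differs from compound 3 by fluoro in place of methyl on an aromatic carbon. This is the same kind of change as that from compound 1 to compound 2, but the surroundings differ: here the place is para to a 1,3-benzoxazol-2-yl group, whereas in the earlier change it was para to a 1,3-benzothiazol-2-yl group.

Since compound 3 shows only a limit, > 14000 nM, the step to compound 4 in this assay is expected to be a step that the limit leaves unreadable from compound 3 to compound 4, again most likely unreadable. The estimate for compound 4 is therefore 20000 nM, between 10000 nM and 50000 nM, with the measurement itself still to come.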

Compound 4, half-maximal effective concentration: > 25000 nM
Compound 4 ended at the assay's limit; the forecaster's own chance of this, stated with the estimate: 80%; middle value at least 1.2-fold (0.09 log units) away from the limit.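

Neither the step from compound 3 to compound 4 nor the step from compound 2 to compound 4 can be read, as all three values are limits of the assay and not numbers. Compound 4 shares its limit with compound 2: the limit of > 25000 nM in this assay, at which 2 of the 4 values shown sit.

The four compounds leave open the concentration at which any of them would show an effect in this assay, and so whether fluoro or methyl, or 1,3-benzoxazol-2-yl or 1,3-benzothiazol-2-yl, makes any difference there.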